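Carboxy for methoxy on the aryl of compound 2

The source may hold more compounds than are shown below. What is called first, only, known or untested is meant among the compounds shown, and "the series" means these compounds.

The series shares one core, seen in compound 1 `O=C1N/C(=C\c2ccc(O)cc2)C(=O)N1c1ccc(I)cc1`, which in a functional assay on NCI-H292 cells (Homo sapiens) for antiproliferative activity (on this read-out lower numbers stand for stronger inhibition and higher numbers for weaker inhibition), gives 25500 nM. Compound 2 `COc1ccc(N2C(=O)N/C(=C\c3ccc(O)cc3)C2=O)cc1` carries a methoxy where compound 1 carries iodo; in this assay compound 2 reaches only the limit > 200000 nM, not a number. Compound 3 `Cc1cccc(N2C(=O)N/C(=C\c3ccc(O)cc3)C2=O)c1` likewise returns only the limit > 200000 nM in this assay. Within the measured set compound 2 therefore stands at the limit of > 200000 nM in this assay, at which 2 of the 3 values shown sit, and nothing places it more closely than that. The steps recorded are an at least 7.8-fold higher number from compound 1 to compound 2 (0.89 log units; beyond the scatter) and an at least 7.8-fold higher number from compound 1 to compound 3 (0.89 log units; beyond the scatter), both pointing away from compound 1 toward weaker inhibition.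

Compound 4 `O=C(O)c1ccc(N2C(=O)N/C(=C\c3ccc(O)cc3)C2=O)cc1` is the next point: carboxy in place of methoxy on an aromatic carbon. Going by the values given here, no measured step covers a carboxy entering this position, so the only bearing comes from the step from compound 1 to compound 2, which shows that changing this aryl substituent moved the number beyond the scatter, and from the fact that compound 2 itself sits at the limit. The step of a number no higher from compound 2 to compound 4 (the limit leaves the size open) is therefore expected to be small relative to a limit value, with the outcome most likely another limit. Compound 4 is estimated in this assay at 200000 nM, within 60000 nM to 600000 nM.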

Compound 4, half-maximal inhibitory concentration: > 200000 nM
Compound 4: only a limit was reported (the forecaster's own chance of this, stated with the estimate: 65%); the middle value lies on the limit itself.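

Carboxy at this place, para to a large group, is the second replacement for iodo that fails to give a number in this assay, and it brings in a hydrogen-bond donor that methoxy lacks. Going from iodo to carboxy gives an at least 7.8-fold higher number from compound 1 to compound 4 (0.89 log units; beyond the scatter), so of the groups shown at this place only iodo, in compound 1, gives a readable value, and neither methoxy nor carboxy does. The step between the methoxy and carboxy compounds cannot be read, and the two cannot be ordered; compound 2, compound 3 and compound 4 all end at one limit, which is not a number: the limit of > 200000 nM in this assay, at which 3 of the 4 values shown sit.

The compounds shown leave open whether the readable value depends on iodo itself or would also appear with another halogen such as bromo or chloro at this place. They also leave open how far the weaker side extends, and since compound 3 differs from compound 1 in both the group and its place on the aryl, the effect of moving iodo alone remains unseparated.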